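The compounds below may be only part of what the source reports. "The series", "measured", "known", "first", "only" and "open" are said of these compounds alone.

Of the compounds shown here, three sharing one core have been measured in a functional assay on A549 cells (Homo sapiens) for cytotoxicity, read by MTT assay, with a stated time of 72 h; on this read-out higher numbers stand for weaker inhibition and lower numbers for stronger inhibition. Compound 1 `COc1c(OCCCCN2CCN(C)CC2)cc(O)c2c(=O)cc(-c3ccc([N+](=O)[O-])cc3)oc12` gives 3210 nM. Compound 2 `COc1c(OCCCCN2CCN(C)CC2)cc(O)c2c(=O)cc(-c3cccc(F)c3)oc12` gives 2090 nM. Compound 3 `CN(C)CCCOc1c(OCc2ccccc2)cc(O)c2c(=O)cc(-c3ccccc3)oc12` gives 2910 nM. Within the data shown here, the only pair among them that differs in a single place shows a 1.5-fold lower number from compound 1 to compound 2 (0.19 log units; within the scatter). Compound 3 therefore stands among the measured numbers with a value that lies within the scatter of both compound 1 and compound 2, so no order among the three can be read from these figures.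

Compound 4 `CCN(CC)CCCOc1c(OCc2ccccc2)cc(O)c2c(=O)cc(-c3ccccc3)oc12` differs from compound 3 by diethylamino in place of dimethylamino on a saturated chain carbon, three bonds along the chain from an oxygen on an aromatic ring. Among the measured compounds shown here, none of the measured steps bears on this change: the one step available concerns an aromatic substituent, not the amine at the end of the chain, and compound 3 has no measured neighbour that differs from it only there. With nothing pointing in either direction, the change is expected to leave the number within the scatter, a 1.0-fold lower number from compound 3 to compound 4 (0.00 log units; within the scatter). Compound 4 is thus estimated at 2900 nM in this assay, with an expected range from 1400 nM to 6000 nM.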

Compound 4, half-maximal inhibitory concentration: 3620 nM
Beside the measured number, compound 4's estimate is 1.2-fold (0.10 log units) below it, within the range that was stated.
By their numbers in this assay, from the lowest: compounds 2, 3, 1 and 4 (each within the scatter of the next).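

In this assay, among these compounds, the one change measured at the amine end of the chain gives a 1.2-fold higher number from compound 3 to compound 4 (0.09 log units; within the scatter). Diethylamino in place of dimethylamino, on a saturated chain carbon three bonds along the chain from an oxygen on an aromatic ring, therefore leaves the number within the scatter, and this pair does not separate the two amines. No accompanying evidence bears on this result.

From the compounds shown here alone, whether a ring amine such as morpholine or pyrrolidine, or a carboxylic acid in place of the amine, would move the number beyond the scatter remains open. Going by these compounds, it is also open whether diethylamino on a longer chain, or the same exchange on a compound with a different aromatic substituent, would give a similarly small step.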